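Swapping an Aromatic Sulfonyl Group for a Saturated Ring

The source may hold more compounds than are shown below. What is called first, only, known or untested is meant among the compounds shown, and "the series" means these compounds.

Within the data shown here, compound 2 `Cc1ccc2[nH]c(C(=O)N[C@H]3CN(S(=O)(=O)c4cn(C)nc4C)C[C@@H]3C(=O)NCCN(C)C)cc2c1` stands highest of the two compounds measured so far in a functional assay on HEK293 cells for agonist activity at growth hormone secretagogue receptor type 1 (Homo sapiens), read by HTRF and inositol phosphate accumulation, with a stated time of 90 min, in the presence of a further agent that is not named here (a higher number here means a larger maximal response, a lower number a smaller maximal response), where compound 2 gives 95%. Among the measured compounds shown here, its only neighbour, compound 1 `Cc1ccc2[nH]c(C(=O)N[C@H]3CN(S(=O)(=O)c4cnccn4)C[C@@H]3C(=O)NCCN(C)C)cc2c1`, gives 92% in this assay, and the step between them, a number 3 percentage points higher from compound 1 to compound 2 (within the scatter), is too small to count as a real difference. Compound 3 `Cc1ccc2[nH]c(C(=O)N[C@H]3CN(S(=O)(=O)C4CCOCC4)C[C@@H]3C(=O)NCCN(C)C)cc2c1` has not yet been measured. It differs from compound 2 in one place: oxan-4-yl in place of 1,3-dimethyl-1H-pyrazol-4-yl on a sulfonyl sulfur. For the measured compounds named here, the single step seen so far bears directly on this change, since it also exchanged one group for another on the same sulfonyl sulfur and left the maximal response in this assay unchanged beyond the scatter. A further exchange at that position, now to a non-aromatic ring, is therefore expected to shift the maximal response little, if at all. Compound 3 is expected to give 92%, within a range from 78% to 102%. The resulting step is expected to read a number 3 percentage points lower from compound 2 to compound 3 (within the scatter).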

Compound 3, largest response reached (Emax), in percent of the reference or control that the assay uses: 90%
Beside the measured number, compound 3's estimate is 2 percentage points above it; the measured number falls inside the stated range.
By their numbers in this assay, from the lowest: compounds 3, 1 and 2 (each within the scatter of the next).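

Compound 3 puts a six-membered non-aromatic ring, oxan-4-yl, on the sulfonyl sulfur, whereas compound 1 and compound 2 both carry aromatic rings there. In this assay this exchange cannot be told apart from either aromatic neighbour (a number 5 percentage points lower from compound 2 to compound 3 (within the scatter); a number 2 percentage points lower from compound 1 to compound 3 (within the scatter)), so across these three compounds an aromatic ring at this position is not needed for the maximal response seen, and none of the three goes against that reading. Nothing measured here accounts for this outcome.

Still open, from the compounds shown here alone, is whether this position would keep that maximal response with no ring at all, as with a simple methyl or a longer alkyl chain, or with a ring carrying a free amine or a carboxylic acid. The maximal response also leaves open how these sulfonyl groups compare in the concentration needed to reach it.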